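The source may hold more compounds than are shown below. What is called first, only, known or untested is meant among the compounds shown, and "the series" means these compounds.

Compound 1 `CC(C)OC(=O)N1CCC(CN(C2Cc3cc(C#N)ccc3N(Cc3cncn3C)C2)S(=O)(=O)c2ccccn2)CC1` gives 1 10^-6 cm/s in an ADME assay on Caco-2 cells (Homo sapiens) for permeability, in the apical to basolateral direction; on this read-out lower numbers stand for lower permeability and higher numbers for higher permeability.
Compound 2 `CC(=O)N1CCC(CN(C2Cc3cc(C#N)ccc3N(Cc3cncn3C)C2)S(=O)(=O)c2ccccn2)CC1` gives 0.5 10^-6 cm/s in this assay.
Compound 3 `Cn1cncc1CN1CC(N(CC2CCN(C(=O)c3ccccc3)CC2)S(=O)(=O)c2ccccn2)Cc2cc(C#N)ccc21` gives 0.5 10^-6 cm/s in this assay.

Compound 3 sits level with compound 2 at the digits shown, and the step of a 2.0-fold lower number from compound 1 to compound 3 (0.30 log units; within the scatter) lies within the usual scatter, so on these numbers the three compounds are not separated from one another.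

The next compound, compound 4 `Cn1cncc1CN1CC(N(CC2CCN(C(=O)c3cccs3)CC2)S(=O)(=O)c2ccccn2)Cc2cc(C#N)ccc21`, differs from compound 3 in one place: thiophen-2-yl in place of phenyl on a carbonyl carbon. All three measured steps change the group on this same carbonyl carbon: a 2.0-fold lower number from compound 1 to compound 2 (0.30 log units; within the scatter), a 2.0-fold lower number from compound 1 to compound 3 (0.30 log units; within the scatter) and no change at the digits printed from compound 2 to compound 3 (within the scatter). None of them moved this assay beyond the scatter, whether a methyl, an isopropoxy or a phenyl sat there. The exchange of phenyl for thiophen-2-yl is a smaller change than any of those, so the expectation for compound 4 is no step beyond the scatter, giving no change at the digits printed from compound 3 to compound 4 (within the scatter). Compound 4 is therefore estimated at 0.5 10^-6 cm/s, with a likely range from 0.25 10^-6 cm/s to 1 10^-6 cm/s.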

Compound 4, apparent permeability: 0.5 10^-6 cm/s
For compound 4 middle estimate and measured number coincide at the digits printed, and the stated range covers the measured number.
By their numbers in this assay, from the lowest: compounds 2, 3, 4 and 1 (each within the scatter of the next).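

In this assay, this position now also takes a five-membered aromatic ring with a sulfur atom, and the steps to compound 4 all stay within the scatter (no change at the digits printed from compound 3 to compound 4 (within the scatter); no change at the digits printed from compound 2 to compound 4 (within the scatter); a 2.0-fold lower number from compound 1 to compound 4 (0.30 log units; within the scatter)). Thiophen-2-yl, with its hetero atom counted as a hydrogen-bond acceptor, thus joins methyl, isopropoxy and phenyl on this carbonyl carbon, and the four compounds remain unseparated. Nothing measured here explains why these exchanges leave the number within the scatter.

From the compounds shown here alone, what remains open is whether a group on this carbonyl carbon that carries an amine or a carboxylic acid would give a step beyond the scatter. Also open, going by these compounds, is whether replacing the nitrile on the shared core, a change away from this carbonyl carbon, would do so.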